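The compounds below may be only part of what the source reports. "The series", "measured", "known", "first", "only" and "open" are said of these compounds alone.

The series rests on a shared core carrying a methoxy group, a fluoro or bromo substituent on the aromatic ring, and a methylated sulfonylurea. Compound 1 `COc1ccc(F)cc1C(C)NC(=O)N(C)S(=O)(=O)c1ccc(C)cc1` is measured in a functional assay on thoracic aorta (Rattus norvegicus, strain Wistar), with a stated time of 15 min (a lower number here means that less compound is needed, a higher number that more compound is needed for the effect), where compound 1 gives 11700 nM. Within the data shown here, its only measured partner is compound 2 `COc1ccc(Br)cc1C(C)NC(=O)N(C)S(=O)(=O)c1ccc(C)cc1`, which in this assay gives 19100 nM. Among the measured compounds shown here, the single step between measured compounds, a 1.6-fold higher number from compound 1 to compound 2 (0.21 log units; within the scatter), is within the scatter, so the two numbers cannot be told apart, and compound 1 stands as one of two indistinguishable points rather than as a clear extreme.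

Compound 3 `CCOc1ccc(F)cc1C(C)NC(=O)N(C)S(=O)(=O)c1ccc(C)cc1` is not yet measured. It differs from compound 1 in one place: methyl in place of hydrogen on a saturated chain carbon bound to an oxygen on an aromatic ring. For the measured compounds named here, no measured step concerns this part of the molecule; the one step available, from fluoro to bromo, touches a different position and was itself within the scatter. The data therefore give no ground to expect a shift beyond the scatter in this assay for compound 3, and the step is estimated as a 1.0-fold higher number from compound 1 to compound 3 (0.01 log units; within the scatter). Compound 3 is expected to give about 12000 nM, with a range from 5000 nM to 30000 nM.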

Compound 3, half-maximal effective concentration: 7800 nM
For compound 3 the middle estimate is 1.5-fold (0.19 log units) above the measured one; the range from low to high includes it.
By their numbers in this assay, from the lowest: compounds 3, 1 and 2 (each within the scatter of the next, the first and the last beyond it).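

Among these compounds, the step from methoxy to ethoxy is the first measured change at this position, and in this assay it amounts to a 1.5-fold lower number from compound 1 to compound 3 (0.18 log units; within the scatter). Methyl in place of hydrogen on a saturated chain carbon bound to an oxygen on an aromatic ring therefore leaves the number within the scatter, so compounds 1 and 3 cannot be told apart in this assay. Together with a 1.6-fold higher number from compound 1 to compound 2 (0.21 log units; within the scatter), this means that neither of the two single changes measured on the core of compound 1 has moved the number beyond the scatter, and no independent evidence accompanies the new step that would help to interpret it.

The compounds shown leave open whether a longer chain on that oxygen, such as propyl, or a branched group such as isopropyl, would produce a step beyond the scatter in this assay. They also leave open what a hydroxyl or an amine at the end of the ethyl chain would do, and whether ethoxy and bromo together on the shared core would give a number distinct from those of the compounds that carry only one of them.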